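Mirror-Image Pairing in a Rice Whole-Organism Test

This account rests on a few compounds, and the source may have more. Where it says the series, first, only, none or still open, it means among the compounds named here.

Two urea compounds have been measured so far. Compound 1, `CC(C)c1ccccc1NC(=O)N[C@@H](C)c1ccccc1`, gives 96% in an ADME assay on the whole organism with Oryza sativa as the target, tested at 1 uM; a higher number here means a weaker effect of the compound at the concentration tested, a lower number a stronger effect. Compound 2, `CC(=O)c1ccccc1NC(=O)N[C@H](C)c1ccccc1`, gives 95% in the same test, and the two numbers lie within the usual scatter of each other, so neither can be called stronger or weaker on this evidence.

The next compound, compound 3, `CC(=O)c1ccccc1NC(=O)N[C@@H](C)c1ccccc1`, has not yet been measured. Its relation to compound 2 is the two compounds have the same atoms and bonds and differ only in configuration as drawn: 1 of 1 stereo elements differ; a stereocentre at a saturated chain carbon is drawn R in compound 2 and S in compound 3, a mirror-image change and nothing more.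

Among the compounds with values here, no measured pair here differs only in configuration, so there is no measured step to lean on for a change of this kind. The two numbers in hand are both high and close together. The estimated step in this assay from compound 2 to compound 3 is a number 1 percentage points lower from compound 2 to compound 3 (within the scatter), essentially none beyond the scatter. Compound 3 is therefore expected to give about 94%, within a range from 82% to 100%.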

Compound 3, a percentage reported as activity, at one concentration (the size of the read-out at that concentration, not a potency): 97%
Estimate against measurement, compound 3: 3 percentage points below, and the stated range covers the measured number.
By their numbers in this assay, from the lowest: compounds 2, 1 and 3 (each within the scatter of the next).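

In this assay, within the data shown here, the first step that changes configuration alone is a number 2 percentage points higher from compound 2 to compound 3 (within the scatter), so turning this saturated chain carbon from R to S gives no difference that can be told from the scatter. With the stereocentre drawn the same way, the step for acetyl in place of isopropyl on an aromatic carbon is a number 1 percentage points higher from compound 1 to compound 3 (within the scatter), so this exchange also stays inside the scatter and the group at this place makes no readable difference so far. The first step can be read as concerning the stereocentre alone because nothing else separates the two compounds: the fact that compounds 2 and 3 differ only in the configuration as drawn.

Going by these compounds, it remains open whether the same holds for the mirror image of compound 1, where isopropyl is the group on the ring. On these data alone, it is also open whether a carboxylic acid or an amine in place of the acetyl would move the number beyond the scatter.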